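The source may report more compounds than this note shows. Statements on the series, on what has been measured and on what is new or still open speak of the compounds shown alone.

Compound 1 `OCCCCC#Cc1ccccc1C#Cc1cccs1`: 1800 nM
Compound 2 `COc1cccc(C#Cc2ccccc2C#CCCCCO)c1`: 1900 nM

In a functional assay on SR cells (Homo sapiens) for cytotoxicity (on this read-out lower numbers stand for stronger inhibition of growth and higher numbers for weaker inhibition of growth), compound 2 gives 1900 nM. On the same read-out compound 1 gives 1800 nM, and the two numbers lie within the scatter of each other, so compound 2 cannot be set apart from compound 1 on what has been measured. Among the compounds with values here, no pair of measured compounds differs in one place only, so no single step is known here.

Compound 3 `OCCCCC#Cc1ccccc1C#Cc1cccc(C(F)(F)F)c1` is the next compound to be measured. Against compound 2 the change is trifluoromethyl in place of methoxy on an aromatic carbon. Nothing in the two measured compounds speaks to this exchange, and with the two measured numbers lying so close together there is no trend to lean on. Compound 3 is therefore expected to give a number close to that of compound 2, with a step of a 1.1-fold lower number from compound 2 to compound 3 (0.02 log units; within the scatter) that is expected to stay within the scatter. The estimate for compound 3 in this assay is 1800 nM, with a range from 700 nM to 4500 nM.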

Compound 3, concentration for 50% growth inhibition: 18300 nM
Compound 3: middle estimate off by 10-fold (1.01 log units), on the low side; measured number above the stated range.
By their numbers in this assay, from the lowest: compounds 1 and 2 (each within the scatter of the next); then compound 3.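

In this assay, trifluoromethyl in place of methoxy on this aromatic carbon brings a 9.6-fold higher number from compound 2 to compound 3 (0.98 log units; beyond the scatter), so the group at this place does bear on the read-out, which the two earlier numbers gave no sign of. The exchange replaces a group of 2 heavy atoms and 1 hydrogen-bond acceptor with one of 4 heavy atoms and no hydrogen-bond acceptor, but this single step cannot show which of these differences matters, if either does. No measurement at hand accounts for the step.

Going by these compounds, it remains open whether an amine, a carboxylic acid or a single fluorine at this place would give a number nearer that of compound 2 or that of compound 3. Also open, on these data alone, is whether a longer chain elsewhere on the shared core would alter the size of this step.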